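Adding a Second Trifluoromethyl Group to Compound 1

This account rests on a few compounds, and the source may have more. Where it says the series, first, only, none or still open, it means among the compounds named here.

Among the measured compounds shown here, in a functional assay on OVCAR-8 cells (Homo sapiens) for inhibition, read by sulforhodamine B assay, with a stated time of 48 h, tested at 100 uM (on this read-out lower numbers stand for a stronger effect and higher numbers for a weaker effect at the one concentration tested), compound 1 `COc1cc(Cl)cc(-c2nn(-c3cccc(NC(=O)Nc4cccc(C(F)(F)F)c4)c3)cc2-c2ccncc2)c1` gives -43%, the lowest of the two numbers measured so far. For the measured compounds named here, its nearest neighbour, compound 2 `COc1cc(Cl)cc(-c2nn(-c3cccc(NC(=O)Nc4ccc(Cl)c(C(F)(F)F)c4)c3)cc2-c2ccncc2)c1`, gives -33% in this assay, and the one measured step, a number 10 percentage points higher from compound 1 to compound 2 (within the scatter), a chloro in place of hydrogen on an aromatic carbon, stays within the scatter. Compound 3 `COc1cc(Cl)cc(-c2nn(-c3cccc(NC(=O)Nc4cc(C(F)(F)F)cc(C(F)(F)F)c4)c3)cc2-c2ccncc2)c1` differs from compound 1 by trifluoromethyl in place of hydrogen on an aromatic carbon. Going by the values given here, since the only comparable step lay within the scatter, the expected step is a number 5 percentage points higher from compound 1 to compound 3 (within the scatter), none beyond the scatter. Compound 3 is therefore estimated at -38%, with a range from -65% to -10%.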

Compound 3, a percentage reported as activity, at one concentration (the size of the read-out at that concentration, not a potency): -62%
Estimate against measurement, compound 3: 24 percentage points above; measured number inside the range.
By their numbers in this assay, from the lowest: compound 3; then compounds 1 and 2 (each within the scatter of the next).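

In this assay, trifluoromethyl in place of hydrogen, on an aromatic carbon meta to a trifluoromethyl group, gives a modest step toward a stronger effect, a number 19 percentage points lower from compound 1 to compound 3 (beyond the scatter). Among the compounds shown here, this is the first step here to pass beyond the scatter; the chloro change, a number 10 percentage points higher from compound 1 to compound 2 (within the scatter), did not. Nothing available explains the step. The compounds shown leave open whether a nitrile or an amine on this carbon would give a similar step. They also leave open whether this single-concentration difference would carry over to potency.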